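The compounds below may be only part of what the source reports. "The series", "measured", "known", "first", "only" and "open" are said of these compounds alone.

Compound 2 `Cc1ccc2[nH]c(=O)c(-c3nc4cc(F)ccc4[nH]3)cc2c1` carries a fluoro group on the shared core, and compound 1 `Cc1ccc2[nH]c(=O)c(-c3nc4ccccc4[nH]3)cc2c1` carries hydrogen at the same place. In a functional assay on SK-OV-3 cells (Homo sapiens) for cytotoxicity, read by MTT assay, with a stated time of 48 h (on this read-out lower numbers stand for stronger inhibition and higher numbers for weaker inhibition), compound 1 gives only a limit of the assay, > 100000 nM. Compound 2 likewise gives only a limit in this assay, > 100000 nM. Both values therefore sit at the limit of > 100000 nM in this assay, at which 2 of the 2 values shown sit, so compound 2 cannot be placed against compound 1, and the step that the two limits leave unreadable from compound 1 to compound 2 cannot be read. Compound 3 `Cc1ccc2[nH]c(=O)c(-c3nc4cc(Cl)ccc4[nH]3)cc2c1` has not yet been measured. It differs from compound 2 in one place: chloro in place of fluoro on an aromatic carbon. Among the measured compounds shown here, the only measured step that bears on this change is a step that the two limits leave unreadable from compound 1 to compound 2, which the two limits leave without a size; it shows only that exchanging hydrogen for fluoro at this carbon did not bring the value inside the measured range. With no readable step to build on, no shift beyond the scatter is expected in this assay from compound 2 to compound 3, estimated as a step that the limit leaves unreadable from compound 2 to compound 3. Compound 3 is therefore expected to give about 150000 nM, with a range from 30000 nM to 600000 nM, and most likely only a limit again.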

Compound 3, half-maximal inhibitory concentration: 33000 nM
The estimate for compound 3 lay 4.5-fold (0.66 log units) above the measured number; the measured number falls inside the stated range.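

Among the compounds shown here, with chloro on this aromatic carbon, the series gives for the first time a number inside the measured range of this assay: the change shows an at least 3.0-fold lower number from compound 2 to compound 3 (0.48 log units; beyond the scatter) and, with hydrogen as the starting point, an at least 3.0-fold lower number from compound 1 to compound 3 (0.48 log units; beyond the scatter). The earlier pair could not show that the group on this carbon makes any difference to the read-out, but this result does, and it also shows that fluoro and chloro are not interchangeable here, even though a single atom is exchanged for a single atom. Both steps are minimum sizes only, as their starting compounds rest at a limit of the assay: the limit of > 100000 nM in this assay, at which 2 of the 3 values shown sit.

On these data alone, the true size of both steps stays unknown, and the step from hydrogen to fluoro cannot be read at all. Also open, as far as these compounds go, is whether a bromo group, a methoxy group or an amine on the same carbon would lower the number further or return it to the limit, and whether chloro would have the same effect on another carbon of this ring.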